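Glycine transporter series: aryl amide variation at the chlorine position

The source may hold more compounds than are shown below. What is called first, only, known or untested is meant among the compounds shown, and "the series" means these compounds.

Measured compounds in an assay on HEK293 cells for inhibition of sodium- and chloride-dependent glycine transporter 1 (Homo sapiens), read by scintillation proximity assay; on this read-out higher numbers stand for weaker inhibition and lower numbers for stronger inhibition:
compound 1 `O=C(CN(C(=O)c1ccc(Cl)cc1)C1CCCCC1)Nc1cc(F)cc(F)c1` gives 631 nM
compound 2 `CC(C(=O)Nc1cc(F)cc(F)c1)N(C(=O)c1ccc(Cl)cc1)C1CCCCC1` gives 3980 nM
compound 3 `O=C(CN(C(=O)c1cccc(Cl)c1)C1CCCCC1)Nc1cc(F)cc(F)c1` gives 1580 nM

Compound 1 has the lowest number of the three in this assay. Its nearest neighbour is compound 3, reached by the step of a 2.5-fold higher number from compound 1 to compound 3 (0.40 log units; beyond the scatter); furthest is compound 2, reached by a 6.3-fold higher number from compound 1 to compound 2 (0.80 log units; beyond the scatter). Both measured changes to the core of compound 1 thus give weaker inhibition, and both steps are beyond the scatter.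

Compound 4 `O=C(CN(C(=O)c1ccc(-c2ccccn2)cc1)C1CCCCC1)Nc1cc(F)cc(F)c1` differs from compound 1 as follows: pyridin-2-yl in place of chloro on an aromatic carbon. Among the measured compounds shown here, neither measured step touches this spot, so no step of the same kind is known. The two steps that do exist show that the core of compound 1 is sensitive to small changes, on the chain and on the chlorophenyl ring, each moving the number upward by a modest amount. A group of six heavy atoms in place of a single chlorine is a larger change than either, and it is expected to shift this assay by a comparable or somewhat larger amount in the same direction, with wide uncertainty.

Compound 4 is therefore expected to give 1600 nM in this assay, within 400 nM to 6300 nM, a step of a 2.5-fold higher number from compound 1 to compound 4 (0.40 log units; beyond the scatter).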

Compound 4, half-maximal inhibitory concentration: 63.1 nM
Compound 4: middle estimate off by 25-fold (1.40 log units), on the high side; measured number below the stated range.
By their numbers in this assay, from the lowest: compound 4; then compound 1; then compound 3; then compound 2.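

In this assay, the aromatic carbon para to a large group accepts much more than a chlorine: pyridin-2-yl, with 6 heavy atoms and 1 hydrogen-bond acceptor in place of 1 heavy atom and none, gives a 10-fold lower number from compound 1 to compound 4 (1.00 log units; beyond the scatter). The earlier changes to the core of compound 1 only raised the number, with a 2.5-fold higher number from compound 1 to compound 3 (0.40 log units; beyond the scatter) and a 6.3-fold higher number from compound 1 to compound 2 (0.80 log units; beyond the scatter), so this is the one place among those shown where a change lowers it, and a larger group at this carbon does not by itself mean weaker inhibition. Nothing at hand tells which part of the pyridin-2-yl group lies behind this step.

Open, going by these compounds, is whether a plain phenyl or a pyridin-3-yl group at this aromatic carbon would give a number close to that of compound 4, which would separate the contribution of the ring from that of its nitrogen. Also open, on these data alone, is whether the rise seen with the methyl on the saturated chain carbon would carry over to a compound bearing pyridin-2-yl.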